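Benzylsulfanyl variation in a pyrimidine-thioether amide series

The compounds below may be only part of what the source reports. "The series", "measured", "known", "first", "only" and "open" are said of these compounds alone.

Three compounds of this series have numbers in a functional assay on the whole organism (artery, strain albino) with Rattus norvegicus as the target, with a stated time of 720 min, at a dose of 10 mg/kg by the oral route; on this read-out higher numbers stand for more inhibition at the one dose given (going by the name of the read-out) and lower numbers for less inhibition. Compound 1 `COc1ccc(C2N=C(SCc3ccc(F)cc3)NC(C)=C2C(=O)Nc2ccc(F)cc2)cc1OC` gives 17%. Compound 2 `CC1=C(C(=O)Nc2ccc(F)cc2)C(c2ccc([N+](=O)[O-])cc2)N=C(SCc2ccccc2Cl)N1` gives 13.9%, and compound 3 `CC1=C(C(=O)Nc2ccc(F)cc2)C(c2ccc([N+](=O)[O-])cc2)N=C(SCc2ccc(Cl)cc2)N1` gives 22.2%. Compound 3 has the highest of the three numbers, but its gaps to compound 1 and to compound 2 both lie within the scatter, so no order among the three can be read from them. Within the data shown here, the one step within the set is a number 8.3 percentage points higher from compound 2 to compound 3 (within the scatter), and it does not rise above the scatter either.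

Compound 4 `CC1=C(C(=O)Nc2ccc(F)cc2)C(c2ccc([N+](=O)[O-])cc2)N=C(SCc2ccc(F)cc2)N1` is the next member. Against compound 3 it differs as follows: fluoro in place of chloro on an aromatic carbon; cut one bond further out, the change reads (4-chlorobenzyl)sulfanyl to (4-fluorobenzyl)sulfanyl. Among the measured compounds shown here, no measured pair in the set shows exactly this exchange; the only step at the same group, a number 8.3 percentage points higher from compound 2 to compound 3 (within the scatter), moved the substituent rather than replacing it and stayed within the scatter. Compound 1 carries the 4-fluorobenzyl group on a different aryl and gives 17%, close to compound 3. For compound 4 the expected step is therefore a number 4.2 percentage points lower from compound 3 to compound 4 (within the scatter), none beyond the scatter. Compound 4 is estimated at 18%, in the range 8% to 28%.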

Compound 4, a percentage reported as inhibition, in the whole organism at one dose (the size of the read-out at that dose, not a potency): 19.6%
The estimate for compound 4 lay 1.6 percentage points below the measured number; the measured number falls inside the stated range.
By their numbers in this assay, from the lowest: compounds 2, 1, 4 and 3 (each within the scatter of the next).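

In this assay, replacing chloro with fluoro on the aromatic carbon gives a number 2.6 percentage points lower from compound 3 to compound 4 (within the scatter), so this direct halogen exchange at the benzyl group leaves the read-out unresolved from the chloro compound. The step with 4-fluorophenyl in place of 2-chlorophenyl on the saturated chain carbon, a number 5.7 percentage points higher from compound 2 to compound 4 (within the scatter), and the step with 4-nitrophenyl in place of 3,4-dimethoxyphenyl on the saturated ring carbon, a number 2.6 percentage points higher from compound 1 to compound 4 (within the scatter), also stay within the scatter, so neither the benzyl substituent nor the aryl on the ring carbon separates any of these compounds at this one dose. No measurement is available here that would explain these small differences.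

The only groups shown on this aromatic carbon are chloro and fluoro, so it remains open whether an amine, a carboxylic acid or a longer chain there would move the number beyond the scatter. A single dose also leaves open how these compounds compare in potency, and whether a pyridine in place of the 4-nitrophenyl would give a number clear of the others.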